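A few compounds are considered here, and "the series" means these few. Any claim that something is new, unique, unknown or untested is made for them only; others in the source may bear on it.

Working notes on the series.

Two compounds of the shared core have numbers in a functional assay on A549 cells (Homo sapiens) for antiproliferative activity, read by MTT assay, with a stated time of 48 h; a higher number here means a weaker inhibitor, a lower number a stronger inhibitor. Compound 1 `COc1ccc(N/C=C\C(=O)c2cn(-c3ccccc3)nc2-c2ccc(OC)cc2)cc1` gives in this assay 6780 nM. Compound 2 `COc1cc(-c2nn(-c3ccccc3)cc2C(=O)/C=C\Nc2ccc(Cl)cc2)cc(OC)c1OC` gives in this assay 8670 nM. These two numbers lie within the scatter of each other, so no order between compound 1 and compound 2 can be read from them; compound 2 simply sits alongside compound 1 at the weak end of what has been seen so far.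

Compound 3 `COc1ccc(N/C=C\C(=O)c2cn(-c3ccccc3)nc2-c2cc(OC)c(OC)c(OC)c2)cc1` is not yet measured in this assay. It differs from compound 2 in one place: methoxy in place of chloro on an aromatic carbon, so that the change reads methoxy in place of chloro on an aromatic carbon, para to a large group. Going by the values given here, no step between measured compounds covers this change, so no measured size is available for it. Compound 1 carries the same methoxy-bearing aniline part as compound 3 and gives this assay a number close to that of compound 2, which argues for a small shift at most.

For compound 3 the expectation is a step of a 1.2-fold lower number from compound 2 to compound 3 (0.06 log units; within the scatter), not beyond the scatter. Compound 3 is therefore estimated at 7500 nM, with a range from 3000 nM to 18000 nM.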

Compound 3, half-maximal inhibitory concentration: 4780 nM
Estimate against measurement, compound 3: 1.6-fold (0.20 log units) above, and the stated range covers the measured number.
By their numbers in this assay, from the lowest: compounds 3, 1 and 2 (each within the scatter of the next).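

Within this assay, the (4-chlorophenyl)amino to (4-methoxyphenyl)amino exchange now has a measured size: methoxy in place of chloro, on an aromatic carbon para to a large group, gives a 1.8-fold lower number from compound 2 to compound 3 (0.26 log units; within the scatter) and so does not separate the two groups at this place. Going by these compounds alone, the compounds also give the first measured step at the other aryl group of the shared core, where 3,4,5-trimethoxyphenyl in place of 4-methoxyphenyl gives a 1.4-fold lower number from compound 1 to compound 3 (0.15 log units; within the scatter) and so does not separate these two groups either. No measurement shown here offers an account of either step.

With only chloro and methoxy seen at the first place, the compounds leave open whether a group of another kind there, such as a primary amine, a carboxylic acid or a longer alkoxy chain, would give a step beyond the scatter in this assay. From the compounds shown here alone, at the other aryl group, only 4-methoxyphenyl and 3,4,5-trimethoxyphenyl can be compared, so the effect of a single hydroxy group or a fluoro group on that ring remains open.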